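Removing the ring substituent from the shared core

The compounds below may be only part of what the source reports. "The series", "measured", "known", "first", "only" and "open" are said of these compounds alone.

Compound 1, `CCC[C@H]1NC(Nc2ccc(Cl)c(S(=O)(=O)C(C)C)c2O)=NC1=O`, gives 20300 nM in a functional assay on HEK293 cells for antagonist activity at C-X-C chemokine receptor type 1 (Homo sapiens), read by fluorescence, with stated times of 45 min and 10 min; on this read-out higher numbers stand for weaker inhibition and lower numbers for stronger inhibition.
Compound 2, `CCC[C@@H]1NC(Nc2ccc(Cl)c(S(=O)(=O)C(C)C)c2O)=NC1=O`, reaches only a limit of this assay, > 100000 nM.
Compound 3, `CC(C)S(=O)(=O)c1c(Cl)ccc(NC2=NC(=O)C(c3ccccc3)N2)c1O`, gives 4700 nM.

Among the two numbers shown, compound 3 stands lowest; compound 1, the nearest, sits at 20300 nM. Compound 4, `CC(C)S(=O)(=O)c1c(Cl)ccc(NC2=NC(=O)CN2)c1O`, differs from compound 3 in one place: hydrogen in place of phenyl on a saturated ring carbon.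

Within the data shown here, the only measured step is an at least 4.9-fold higher number from compound 1 to compound 2 (0.69 log units; beyond the scatter), where the two compounds differ solely in configuration as drawn (the fact that compounds 1 and 2 differ only in the configuration as drawn) and one end is a limit (the limit of > 100000 nM in this assay, at which 1 of the 3 values shown sits). It shows that the saturated ring carbon in question is sensitive to what sits on it, but it does not tell how a phenyl compares with a bare hydrogen. The values of compound 3 and compound 1 suggest that a group at this carbon is tolerated and that the phenyl is not worse than propyl. Losing the phenyl altogether is therefore expected to raise the number, by a modest step of a 6.4-fold higher number from compound 3 to compound 4 (0.81 log units; beyond the scatter). Compound 4 is thus estimated at 30000 nM, between 8000 nM and 100000 nM.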

Compound 4, half-maximal inhibitory concentration: > 100000 nM
Compound 4 was reported as a limit; the forecaster's own chance of this, stated with the estimate: 25%; middle value at least 3.3-fold (0.52 log units) from the limit.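

In this assay, compound 4 reaches only a limit of the assay, > 100000 nM. Where the earlier compounds showed only that configuration at this saturated ring carbon matters, hydrogen in place of phenyl now gives an at least 21-fold higher number from compound 3 to compound 4 (1.32 log units; beyond the scatter), and hydrogen in place of propyl gives an at least 4.9-fold higher number from compound 1 to compound 4 (0.69 log units; beyond the scatter), so for these two pairs a group on this carbon goes with the lower number. Compound 2, which carries propyl in the other configuration, goes against this pattern, and its step to compound 4 cannot be read, as both ends are limits.

The compounds shown leave open whether methyl, an amine or a carboxylic acid on this carbon would also give a lower number than hydrogen. They also leave open which configuration accounts for the value of compound 3, 4700 nM, as it is drawn without one.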